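Nitrile for fluorine on the sulfonyl aryl of compound 3

This account rests on a few compounds, and the source may have more. Where it says the series, first, only, none or still open, it means among the compounds named here.

The measured compounds:
compound 1, `CN(C)c1ccc(C2CC(c3ccc(-n4cncn4)cc3)=NN2C(=O)c2ccc(C(F)(F)F)cc2)cc1`, 11.5%
compound 2, `CN(C)c1ccc(C2CC(c3ccc(-n4cncn4)cc3)=NN2C(=O)/C=C/c2ccccc2)cc1`, -2.3%
compound 3, `CN(C)c1ccc(C2CC(c3ccc(-n4cncn4)cc3)=NN2S(=O)(=O)c2ccc(F)cc2)cc1`, -0.5%

In a functional assay on NCI-H1975 cells (Homo sapiens) for inhibition, read by sulforhodamine B assay, tested at 10 uM (a higher number here means more inhibition at the concentration tested (going by the name of the read-out), a lower number less inhibition), compound 3 stands second highest of the three numbers. Its nearest neighbour is compound 2, a gap within the scatter, as the step of a number 1.8 percentage points higher from compound 2 to compound 3 (within the scatter) shows. Its furthest is compound 1, and the step of a number 12 percentage points lower from compound 1 to compound 3 (beyond the scatter) lies beyond the scatter. The other step among the measured compounds is a number 13.8 percentage points lower from compound 1 to compound 2 (beyond the scatter).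

Compound 4 is `CN(C)c1ccc(C2CC(c3ccc(-n4cncn4)cc3)=NN2S(=O)(=O)c2ccc(C#N)cc2)cc1`. It differs from compound 3 in one place: cyano in place of fluoro on an aromatic carbon. For the measured compounds named here, none of the measured steps touches this position. The steps of a number 12 percentage points lower from compound 1 to compound 3 (beyond the scatter) and a number 1.8 percentage points higher from compound 2 to compound 3 (within the scatter) exchange the whole group on the ring nitrogen, not a substituent on the aryl ring of the sulfonyl, so they do not bear directly on a cyano in place of a fluoro. Going by the values given here, with no step of this kind to lean on, the expected change is none beyond the scatter, and the step of a number 2.5 percentage points higher from compound 3 to compound 4 (within the scatter) is therefore estimated to be small.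

Compound 4 is expected to give 2% in this assay, within a range from -10% to 14%.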

Compound 4, a percentage reported as inhibition, at one concentration (the size of the read-out at that concentration, not a potency): 22.6%
Compound 4: middle estimate off by 20.6 percentage points, on the low side; measured number above the stated range.
By their numbers in this assay, from the lowest: compounds 2 and 3 (each within the scatter of the next); then compound 1; then compound 4.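

In this assay, for the compounds shown here, the substituent on the aryl ring of the sulfonyl proves to be a position that matters: cyano in place of fluoro gives a number 23.1 percentage points higher from compound 3 to compound 4 (beyond the scatter) and is the first measured change at this place. It also alters how the groups on the ring nitrogen rank, since the (4-cyanophenyl)sulfonyl group gives a number 24.9 percentage points higher from compound 2 to compound 4 (beyond the scatter) and, against the (4-(trifluoromethyl)phenyl)carbonyl group, a number 11.1 percentage points higher from compound 1 to compound 4 (beyond the scatter), so the low standing of the sulfonyl in compound 3 belongs to the (4-fluorophenyl)sulfonyl group and not to every sulfonyl. Nothing shown accounts for the effect of this exchange on the read-out.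

The compounds shown leave open whether the rise is special to the nitrile or would also appear with another group at this place, such as a methoxy group, an amine or a carboxylic acid, and whether a nitrile on the aryl ring of the carbonyl series would act in the same way. From the compounds shown here alone, each number is also a reading at one concentration, so the potency of compound 4 remains unknown.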